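This account rests on a few compounds, and the source may have more. Where it says the series, first, only, none or still open, it means among the compounds named here.

Compounds measured so far: compound 1 `Cc1cc(Nc2cc(-c3ccccc3)[nH]n2)n2ncnc2n1`, compound 2 `Cc1cc(Nc2cc(-c3ccccc3)[nH]n2)n2nc(SCCc3ccccc3)nc2n1`, compound 3 `Cc1cc(Nc2cc(-c3ccccc3)[nH]n2)n2nc(SCc3ccccc3Br)nc2n1`.

In a functional assay on MGC-803 cells (Homo sapiens) for inhibition, read by MTT assay, with a stated time of 72 h (a higher number here means a weaker inhibitor, a lower number a stronger inhibitor), compound 1 gives 21700 nM, compound 2 gives 5620 nM and compound 3 gives 3650 nM. Compound 3 stands at the lowest number of the three, with compound 2 nearest to it and compound 1 furthest away. Compound 4 `CCCSc1nc2nc(C)cc(Nc3cc(-c4ccccc4)[nH]n3)n2n1` differs from compound 3 by ethyl in place of 2-bromophenyl on a saturated chain carbon bound to a sulfur. Within the data shown here, the steps that bear on this are a 5.9-fold lower number from compound 1 to compound 3 (0.77 log units; beyond the scatter) and a 3.9-fold lower number from compound 1 to compound 2 (0.59 log units; beyond the scatter), both of which show that a sulfanyl group carrying a ring lowers the number, while a 1.5-fold lower number from compound 2 to compound 3 (0.19 log units; within the scatter) shows little separation between the two ring-bearing groups. Compound 4 keeps a sulfanyl group but loses its ring, so its number is expected to rise somewhat, giving an estimated 2.2-fold higher number from compound 3 to compound 4 (0.34 log units; beyond the scatter). Compound 4 is estimated at 8000 nM, within 3500 nM to 20000 nM.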

Compound 4, half-maximal inhibitory concentration: 12600 nM
Compound 4: the middle estimate sits 1.6-fold (0.20 log units) below what was measured, and the stated range covers the measured number.
By their numbers in this assay, from the lowest: compounds 3 and 2 (each within the scatter of the next); then compounds 4 and 1 (each within the scatter of the next).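

In this assay, a sulfanyl group without a ring does little at this position: with propylsulfanyl in place of hydrogen there is a 1.7-fold lower number from compound 1 to compound 4 (0.24 log units; within the scatter), whereas both ring-bearing groups stood beyond the scatter from compound 1. Losing the ring gives a 3.5-fold higher number from compound 3 to compound 4 (0.54 log units; beyond the scatter) and a 2.2-fold higher number from compound 2 to compound 4 (0.35 log units; beyond the scatter), so among these four compounds the lower numbers go with a ring on the chain rather than with the sulfur alone. As far as these compounds go, whether a longer chain could match the ring remains open. So does whether an unsubstituted benzyl or a chain ending in an amine would hold the number of compound 3. No measurement shown here explains these differences.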